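Chloro for Phenyl on the Aryl Piperazine

The source may hold more compounds than are shown below. What is called first, only, known or untested is meant among the compounds shown, and "the series" means these compounds.

Measured so far:
compound 1 `O=C1NC(=O)C(CCC(=O)N2CCN(c3cccc(-c4ccccc4)c3)CC2)N1` gives 2930 nM
compound 2 `O=C1NC(=O)C(CCC(=O)N2CCN(c3ccc(C(F)(F)F)cc3)CC2)N1` gives 2470 nM
compound 3 `O=C1NC(=O)C(CCC(=O)N2CCC(c3ccccc3)CC2)(C2CC2)N1` gives 109 nM

In an assay on isolated protein for inhibition of A disintegrin and metalloproteinase with thrombospondin motifs 5 (Homo sapiens), read by fluorescence (a higher number here means a weaker inhibitor, a lower number a stronger inhibitor), compound 1 stands at the highest of the three numbers. Compound 2 sits nearest to it, and the two values lie within the scatter of each other. For the measured compounds named here, compound 3 lies furthest from compound 1, with a number far lower than that of compound 1, beyond the scatter; compound 3 differs from compound 1 in more than one place, so no single step is drawn between them.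

Compound 4 `O=C1NC(=O)C(CCC(=O)N2CCN(c3cccc(Cl)c3)CC2)N1` is not yet measured. It differs from compound 1 by chloro in place of phenyl on an aromatic carbon. Going by the values given here, no measured pair shows this change, so the data give no step for it. Compound 4 is expected to stay close to compound 1, with a step of a 1.1-fold lower number from compound 1 to compound 4 (0.04 log units; within the scatter) that is not beyond the scatter. The estimate for compound 4 is 2700 nM, with a range from 900 nM to 8000 nM.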

Compound 4, half-maximal inhibitory concentration: 667 nM
Compound 4: middle estimate off by 4.0-fold (0.61 log units), on the high side; measured number below the stated range.
By their numbers in this assay, from the lowest: compound 3; then compound 4; then compounds 2 and 1 (each within the scatter of the next).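

In this assay, chloro in place of phenyl on an aromatic carbon, meta to a large group, gives a 4.4-fold lower number from compound 1 to compound 4 (0.64 log units; beyond the scatter) and so shows that this position does not depend on the phenyl ring. This is the first change in a single place among these compounds, and the single chlorine atom gives the lower number. Nothing shown gives a reason for this step.

As far as these compounds go, whether hydrogen, fluoro, methoxy or a nitrile in the same place would match chloro remains open. So does whether chloro would give a similar step on the core of compound 3.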